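Chloro for Cyano: Expected Clearance of Compound 3

The source may hold more compounds than are shown below. What is called first, only, known or untested is meant among the compounds shown, and "the series" means these compounds.

Measured compounds:
compound 1, `CCC1c2cc(Cl)ccc2C(=O)N1c1cccnc1`, 6.6 mL/min/kg
compound 2, `N#Cc1ccc2c(c1)CN(c1cccnc1)C2=O`, 8.7 mL/min/kg

Of the compounds shown here, two have been measured in an ADME assay on microsomes from liver (Homo sapiens) for metabolic stability, read by LC-MS, using NADPH, with stated times of 10 min and 30 min; on this read-out higher numbers stand for fast clearance and lower numbers for slow clearance. Compound 1 `CCC1c2cc(Cl)ccc2C(=O)N1c1cccnc1` gives 6.6 mL/min/kg in this assay, and compound 2 `N#Cc1ccc2c(c1)CN(c1cccnc1)C2=O` gives 8.7 mL/min/kg. Among the measured compounds shown here, on these two numbers compound 2 and compound 1 lie within the usual scatter of each other, so neither can be set apart from the other; the pair offers no step that can be read as a real difference.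

Compound 3 `O=C1c2ccc(Cl)cc2CN1c1cccnc1` is not yet measured. It differs from compound 2 in one place: chloro in place of cyano on an aromatic carbon. For the measured compounds named here, no measured pair shows a change of this kind alone, since compound 1 and compound 2 differ in more than one place. With nothing to draw on beyond the two numbers shown, no shift beyond the scatter is expected in this assay from compound 2 to compound 3, and the step of a 1.2-fold lower number from compound 2 to compound 3 (0.06 log units; within the scatter) is an estimate that stays inside it. Compound 3 is accordingly expected to give about 7.5 mL/min/kg in this assay, with a range from 4 mL/min/kg to 15 mL/min/kg.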

Compound 3, clearance in the Homo sapiens assay: 12.8 mL/min/kg
Compound 3: the middle estimate sits 1.7-fold (0.23 log units) below what was measured; the range from low to high includes it.
By their numbers in the Homo sapiens assay, from the lowest: compounds 1, 2 and 3 (each within the scatter of the next).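

In the Homo sapiens assay, chloro in place of cyano on an aromatic carbon gives a 1.5-fold higher number from compound 2 to compound 3 (0.17 log units; within the scatter), and hydrogen in place of ethyl on a saturated ring carbon gives a 1.9-fold higher number from compound 1 to compound 3 (0.29 log units; within the scatter), so neither change can be told apart from repeat measurement in this read-out. The position is nonetheless not a silent one, for in a physicochemical assay for lipophilicity, measured as octanol-water partition (a lower number here means a more polar compound, a higher number a more lipophilic compound), compound 2 gives 1.35 and compound 3 gives 2.52, a large difference from one change on the aromatic carbon, while the clearance numbers stay within the scatter of each other. Chloro in place of cyano at this position therefore makes the compound clearly more lipophilic without a readable shift in clearance: the measured distribution coefficient of compound 2, 1.35, and of compound 3, 2.52, a number 1.17 log units higher (beyond the scatter)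

As far as these compounds go, whether a group such as trifluoromethyl or a longer chain on the same aromatic carbon would carry clearance beyond the scatter remains open. So does whether an amine or a carboxylic acid there would move clearance in the opposite direction, since the steps shown give no readable direction for it.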